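A few compounds are considered here, and "the series" means these few. Any claim that something is new, unique, unknown or untested is made for them only; others in the source may bear on it.

Compound 2 `COc1ccccc1N1C(=O)/C(=C/c2ccc(OCc3ccc(C(=O)O)cc3)cc2)SC1=S` gives 2000 nM in an assay on isolated protein for inhibition of Apoptosis regulator Bcl-2 (Homo sapiens), read by fluorescence polarization (a higher number here means a weaker inhibitor, a lower number a stronger inhibitor), and so stands lowest of the two numbers; its nearest neighbour, compound 3 `COc1ccccc1N1C(=O)/C(=C/c2ccc(OCC(=O)Nc3ccc(C(=O)O)cc3)cc2)SC1=S`, gives 10000 nM in this assay, a step of a 5.0-fold higher number from compound 2 to compound 3 (0.70 log units; beyond the scatter). Compound 1 `Cc1ccccc1N1C(=O)/C(=C/c2ccc(OCC(=O)Nc3ccc(C(=O)O)cc3)cc2)SC1=S` reports a limit rather than a number, > 10000 nM in this assay, as noted in the limit of > 10000 nM in this assay, at which 1 of the 3 values shown sits. The methoxy-for-methyl step from compound 1 to compound 3 is therefore a number no higher from compound 1 to compound 3 (the limit leaves the size open). Compound 4 `O=C(O)c1ccc(COc2ccc(/C=C3\SC(=S)N(c4ccc([N+](=O)[O-])cc4)C3=O)cc2)cc1` differs from compound 2 by 4-nitrophenyl in place of 2-methoxyphenyl on an amide-type nitrogen in a ring. For the measured compounds named here, neither measured step touches this position, so no size can be carried over directly; the one numeric step available, a 5.0-fold higher number from compound 2 to compound 3 (0.70 log units; beyond the scatter), was modest. Compound 4 is expected to give 2000 nM in this assay, with a range of 500 nM to 8000 nM. That estimate means a step of no change at the digits printed from compound 2 to compound 4 (within the scatter), expected to stay within the scatter.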

Compound 4, inhibition constant: > 10000 nM
Compound 4: only a limit was reported (the forecaster's own chance of this, stated with the estimate: 15%); at least 5.0-fold (0.69 log units) between middle value and limit.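

For the compounds shown here, the amide-type nitrogen in a ring, which no earlier step touched, does not tolerate every aryl group: 4-nitrophenyl in place of 2-methoxyphenyl gives an at least 5.0-fold higher number from compound 2 to compound 4 (0.69 log units; beyond the scatter). The value of compound 4, > 10000 nM, is a limit, so the true size of this loss stays unread. Compound 4 thus sits at the same limit as compound 1: the limit of > 10000 nM in this assay, at which 2 of the 4 values shown sit.

The step changes the group and its substitution pattern together, so neither can be credited alone. As far as these compounds go, whether plain phenyl, 4-methoxyphenyl or 2-nitrophenyl would hold the level of compound 2 remains open.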